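Adding a Hydroxybutyl Chain at the Branching Carbon of Compound 1

A few compounds are considered here, and "the series" means these few. Any claim that something is new, unique, unknown or untested is made for them only; others in the source may bear on it.

Compound 1 `O=C(O)COc1cccc(CCc2nc(-c3ccccc3)c(-c3ccccc3)o2)c1` is the reference point of this short series. Going by the values given here, in a functional assay for inhibition, with Homo sapiens as the target (on this read-out higher numbers stand for weaker inhibition and lower numbers for stronger inhibition), compound 1 gives 1200 nM, the second highest of the three numbers known so far. Its two measured relatives differ from it at one place only. Compound 2 `CCOC(=O)C(Cc1cccc(OCC(=O)O)c1)c1nc(-c2ccccc2)c(-c2ccccc2)o1` carries ethoxycarbonyl at that place and in this assay gives 120 nM; the step is a 10-fold lower number from compound 1 to compound 2 (1.00 log units; beyond the scatter). Compound 3 `O=C(O)COc1cccc(CC(c2nc(-c3ccccc3)c(-c3ccccc3)o2)c2cccs2)c1` carries thiophen-2-yl at the same place and in this assay gives 33200 nM; the step is a 28-fold higher number from compound 1 to compound 3 (1.44 log units; beyond the scatter), and the comparison between the two substituted compounds is a 280-fold higher number from compound 2 to compound 3 (2.44 log units; beyond the scatter).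

Compound 4 `O=C(O)COc1cccc(CC(CCCCO)c2nc(-c3ccccc3)c(-c3ccccc3)o2)c1` has not yet been measured. It differs from compound 1 by 4-hydroxybutyl in place of hydrogen on a saturated chain carbon bound to an aromatic carbon and a saturated chain carbon. Both measured steps at this place bear on the question, and they point in opposite directions: one substituent brought a modest gain, the other a large loss. A 4-hydroxybutyl group is neither of these, so the data give no clear direction, and the expected step is best taken as small, with a wide range in either direction. Compound 4 is expected to give 700 nM in this assay, with a range from 80 nM to 6000 nM. That estimate amounts to an expected step of a 1.7-fold lower number from compound 1 to compound 4 (0.23 log units; within the scatter).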

Compound 4, half-maximal inhibitory concentration: 4680 nM
Beside the measured number, compound 4's estimate is 6.7-fold (0.83 log units) below it; the measured number falls inside the stated range.
By their numbers in this assay, from the lowest: compound 2; then compound 1; then compound 4; then compound 3.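

At the saturated chain carbon bound to an aromatic carbon and a saturated chain carbon, 4-hydroxybutyl gives in this assay a 3.9-fold higher number from compound 1 to compound 4 (0.59 log units; beyond the scatter), so thiophen-2-yl is no longer the only substituent that raises the number over hydrogen, and ethoxycarbonyl remains the only one of the three that lowers it. The new chain also separates the two earlier substituents, with a 7.1-fold lower number from compound 3 to compound 4 (0.85 log units; beyond the scatter) on one side and a 39-fold higher number from compound 2 to compound 4 (1.59 log units; beyond the scatter) on the other, which shows that the read-out at this place depends strongly on which group enters, and that filling the place with an open chain rather than a ring does not by itself restore the number of compound 1. No evidence is available on what lies behind these differences.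

The compounds shown leave open whether the lower number of compound 2 belongs to the ethyl ester as a whole or would persist with a carboxylic acid or an amide at this place. They also do not tell how the number would respond to a shorter or longer chain than 4-hydroxybutyl, or to the same chain ending in an amine instead of a hydroxyl.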